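The source may report more compounds than this note shows. Statements on the series, on what has been measured and on what is new or still open speak of the compounds shown alone.

In a functional assay on DU-145 cells (Homo sapiens) for inhibition, read by trypan blue exclusion, with a stated time of 72 h (a lower number here means a stronger inhibitor, a higher number a weaker inhibitor), compound 1 `Cn1c(=O)c(S(=O)(=O)c2ccc(Cl)cc2Cl)cc2cnc(Nc3ccc4[nH]ccc4c3)nc21` gives 1000 nM and compound 2 `Cn1ccc2cc(Nc3ncc4cc(S(=O)(=O)c5ccc(F)cc5F)c(=O)n(C)c4n3)ccc21` gives 750 nM. For the measured compounds named here, these are the only two numbers so far, and they lie within the usual scatter of each other, so compound 2 stands level with compound 1.

Compound 3 `Cn1ccc2cc(Nc3ncc4cc(S(=O)(=O)c5ccc(Cl)cc5Cl)c(=O)n(C)c4n3)ccc21` differs from compound 2 in one place: 2,4-dichlorophenyl in place of 2,4-difluorophenyl on a sulfonyl sulfur. In words, 2,4-dichlorophenyl sits in place of 2,4-difluorophenyl on a sulfonyl sulfur. Going by the values given here, no measured pair shows this change on its own, so the evidence is indirect. Compound 1 also carries 2,4-dichlorophenyl on a sulfonyl sulfur and gives 1000 nM, so no step beyond the scatter is expected in this assay. The expected step is a 1.1-fold higher number from compound 2 to compound 3 (0.03 log units; within the scatter). For compound 3 the estimated value is 800 nM, with an expected range from 300 nM to 2000 nM.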

Compound 3, half-maximal inhibitory concentration: 750 nM
The estimate for compound 3 lay 1.1-fold (0.03 log units) above the measured number, and the stated range covers the measured number.
By their numbers in this assay, from the lowest: compounds 2, 3 and 1 (each within the scatter of the next).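

Measured directly, 2,4-dichlorophenyl in place of 2,4-difluorophenyl on a sulfonyl sulfur gives no change at the digits printed from compound 2 to compound 3 (within the scatter) in this assay, so the two groups stand level at this position in this assay. A second single change, methyl in place of hydrogen on an aromatic nitrogen, gives a 1.3-fold lower number from compound 1 to compound 3 (0.12 log units; within the scatter), so with 2,4-dichlorophenyl in place, these two compounds cannot be told apart either. No measurement here offers an explanation for these level results.

Both sulfonyl groups shown are phenyl rings carrying two halogens, so it remains open what an unsubstituted phenyl, a methoxyphenyl or a simple methyl would do on that sulfur. On these data alone, it is also open whether a longer chain, such as propyl, or one ending in an amine, would stand level with methyl on the aromatic nitrogen.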